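Swapping Chloro for Amino on an Indole Amidine

The compounds below may be only part of what the source reports. "The series", "measured", "known", "first", "only" and "open" are said of these compounds alone.

Measured compounds:
- Compound 1, `Cc1cc(Cl)cc(-c2cc3cc(C(=N)N)ccc3[nH]2)c1`: 87%
- Compound 2, `N=C(N)c1ccc2[nH]c(-c3cc(Cl)cc(Cl)c3)cc2c1`: 92%

Both compounds were tested in an assay on isolated protein for inhibition of acid-sensing ion channel 3 (Homo sapiens), read by patch clamp, tested at 1 uM; on this read-out higher numbers stand for more inhibition at the one concentration tested (going by the name of the read-out) and lower numbers for less inhibition. In this assay, among the measured compounds shown here, compound 1 gives 87% and compound 2 gives 92%; the only step recorded, a number 5 percentage points higher from compound 1 to compound 2 (within the scatter), lies within the scatter, so the two numbers cannot be told apart.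

Compound 3, `N=C(N)c1ccc2[nH]c(-c3cc(N)cc(Cl)c3)cc2c1`, is not yet measured. It differs from compound 2 by amino in place of chloro on an aromatic carbon. For the measured compounds named here, no measured step describes this exchange: the one step available replaced methyl by chloro at the same place and changed the number by only a few points. That step shows that two different small groups at this place give numbers that cannot be told apart, but an amino group is a third kind of group and its effect on the number is not covered.

Compound 3 is therefore expected to come in somewhat lower, by a number 22 percentage points lower from compound 2 to compound 3 (beyond the scatter), with a wide range. The estimate for compound 3 in this assay is 70%, between 45% and 92%.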

Compound 3, a percentage reported as inhibition, at one concentration (the size of the read-out at that concentration, not a potency): 78%
Estimate against measurement, compound 3: 8 percentage points below; the measured number falls inside the stated range.
By their numbers in this assay, from the lowest: compounds 3, 1 and 2 (each within the scatter of the next, the first and the last beyond it).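

The exchange of chloro for amino gives a number 14 percentage points lower from compound 2 to compound 3 (beyond the scatter) in this assay, so the group on this aromatic carbon can move the number by more than the scatter, which the step from methyl to chloro did not show. Set against the methyl group, however, the same amino group gives a number 9 percentage points lower from compound 1 to compound 3 (within the scatter) and the two compounds cannot be told apart, so the change is visible only against chloro. Compound 3 still gives 78% at the one concentration tested, so at this place a group with a hydrogen-bond donor and acceptor retains much of the inhibition seen with chloro, which has neither.

Going by these compounds, three small groups at one position give no trend, and it remains open how a hydroxyl, a methoxy, a fluoro or a dimethylamino group would read here, or what would happen if the remaining chloro group were exchanged as well. These single-concentration numbers also leave the potency of the compounds unknown, and no measurement at hand accounts for the lower number with amino.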